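The source may report more compounds than this note shows. Statements on the series, on what has been measured and on what is new or still open speak of the compounds shown alone.

Measured in a functional assay on A549 cells (Homo sapiens) for inhibition, read by MTT assay, with a stated time of 48 h; on this read-out higher numbers stand for weaker inhibition and lower numbers for stronger inhibition:

- compound 1 `C#CCNC(=O)/C=C/c1c(/C=C/c2ccc(OC)cc2)cc(OC)cc1OC` gives 6930 nM
- compound 2 `COc1ccc(/C=C/c2cc(OC)cc(OC)c2/C=C/C(=O)N2CCC(Cl)CC2)cc1` gives 2080 nM
- compound 3 `CCCCN(CCCC)C(=O)/C=C/c1c(/C=C/c2ccc(OC)cc2)cc(OC)cc1OC` gives 6160 nM

Compound 3, at 6160 nM, sits level with compound 1, since a 1.1-fold lower number from compound 1 to compound 3 (0.05 log units; within the scatter). Compound 2 has the lowest number of the three, and a 3.0-fold higher number from compound 2 to compound 3 (0.47 log units; beyond the scatter).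

The next compound, compound 4 `COc1ccc(/C=C/c2cc(OC)cc(OC)c2/C=C/C(=O)N(CC(C)C)CC(C)C)cc1`, keeps the shared core and changes only the amide group: diisobutylamino in place of dibutylamino on a carbonyl carbon. The two groups hold the same atoms, joined differently.

Among the measured compounds shown here, no measured pair tests this exact swap, so the other amide changes are the only guide. The closest is a 1.1-fold lower number from compound 1 to compound 3 (0.05 log units; within the scatter), which swaps one open-chain group for another. The larger steps, a 3.3-fold lower number from compound 1 to compound 2 (0.52 log units; beyond the scatter) and a 3.0-fold higher number from compound 2 to compound 3 (0.47 log units; beyond the scatter), both involve the ring-bearing 4-chloropiperidin-1-yl group, which is absent here. No step beyond the scatter is therefore expected, and the estimated change is a 1.1-fold lower number from compound 3 to compound 4 (0.05 log units; within the scatter).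

For compound 4 the estimated value is 5500 nM, with an expected range from 2500 nM to 12000 nM.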

Compound 4, half-maximal inhibitory concentration: 3350 nM
Compound 4: the middle estimate sits 1.6-fold (0.22 log units) above what was measured; the range from low to high includes it.
By their numbers in this assay, from the lowest: compounds 2, 4, 3 and 1 (each within the scatter of the next, the first and the last beyond it).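

In this assay, joining the same atoms differently, as diisobutylamino in place of dibutylamino on the carbonyl carbon, gives a step that stays within the usual scatter (a 1.8-fold lower number from compound 3 to compound 4 (0.26 log units; within the scatter)), so this rearrangement shows no clear effect at this position. Compound 4 also cannot be separated from compound 2 (a 1.6-fold higher number from compound 2 to compound 4 (0.21 log units; within the scatter)), although compound 3 could be, so an open-chain group here can read level with the 4-chloropiperidin-1-yl group. Compound 3 sat level with compound 1, yet diisobutylamino gives a modest step beyond the scatter from the propargylamino group (a 2.1-fold lower number from compound 1 to compound 4 (0.32 log units; beyond the scatter)).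

As far as these compounds go, whether morpholin-4-yl or a longer chain such as dihexylamino on the same carbonyl carbon would read differently remains open. Nothing shown explains why these values fall as they do.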